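A few compounds are considered here, and "the series" means these few. Any claim that something is new, unique, unknown or untested is made for them only; others in the source may bear on it.

Measured compounds:
Compound 1, `CC(Sc1nnc(-c2ccncc2)s1)C(=O)Nc1ccc(Cl)cc1Cl`: in an ADME assay on HepG2 cells (Homo sapiens) for cytotoxicity, with a stated time of 3 days (a higher number here means that more compound is tolerated, a lower number that less compound is tolerated), compound 1 gives > 50000 nM, a limit of the assay and not a number.
Compound 2, `O=C(CCSc1nnc(-c2ccncc2)s1)Nc1ccc(Cl)cc1`: in this assay compound 2 gives 7260 nM.

Compound 2 holds the only number shown in this assay, while the value of compound 1 is a limit; the two were not compared as a step, and they differ in more than one place, so their values stand side by side without a measured link. Compound 3, `O=C(CCSc1nnc(-c2ccncc2)s1)Nc1c(Cl)cccc1Cl`, is not yet measured. It differs from compound 2 in one place: 2,6-dichlorophenyl in place of 4-chlorophenyl on an amide-type nitrogen. Among the measured compounds shown here, no measured step covers a change of this kind. The account therefore expects a small shift in this assay for the step of a 2.1-fold higher number from compound 2 to compound 3 (0.32 log units; beyond the scatter), towards more tolerated, leaning on compound 1 with its dichlorophenyl at > 50000 nM. For compound 3 the estimate is 15000 nM, with a range from 5000 nM to 50000 nM.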

Compound 3, half-maximal cytotoxic concentration: 12600 nM
For compound 3 the middle estimate is 1.2-fold (0.08 log units) above the measured one; measured number inside the range.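

Replacing 4-chlorophenyl with 2,6-dichlorophenyl on the amide-type nitrogen gives, in this assay, a 1.7-fold higher number from compound 2 to compound 3 (0.24 log units; within the scatter). Among the compounds shown here, this is the first measured step at this place, and it shows that the two groups cannot be told apart in this assay, even though the entering group carries a second chlorine. Compound 1 also bears a dichlorophenyl, but it differs from compound 3 in more than one place, and its value is a limit of the assay and not a number: the limit of > 50000 nM in this assay, at which 1 of the 3 values shown sits.

The compounds shown leave open how this place would respond to a group without chlorine, such as an unsubstituted phenyl, or to a phenyl carrying a carboxylic acid or an amine. They also leave open what the methyl branch on the chain of compound 1 contributes on its own.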